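This account rests on a few compounds, and the source may have more. Where it says the series, first, only, none or still open, it means among the compounds named here.

Compound 1, `O=C(Nc1ccc(Oc2ccnc3[nH]ccc23)c(F)c1)c1cc(-c2ccccc2)ccn1`, gives 4950 nM in a functional assay on A549 cells (Homo sapiens) for cytotoxicity, read by MTT assay, with a stated time of 72 h; on this read-out higher numbers stand for weaker inhibition and lower numbers for stronger inhibition.
Compound 2, `CCc1ccc(-c2ccnc(C(=O)Nc3ccc(Oc4ccnc5[nH]ccc45)c(F)c3)c2)cc1`, gives 3370 nM in this assay.
Compound 3, `COc1ccc(-c2ccnc(C(=O)Nc3ccc(Oc4ccnc5[nH]ccc45)c(F)c3)c2)cc1`, gives 1040 nM in this assay.

Of these three numbers, compound 3 has the lowest. One step is a 3.2-fold lower number from compound 2 to compound 3 (0.51 log units; beyond the scatter), and the other is a 4.8-fold lower number from compound 1 to compound 3 (0.68 log units; beyond the scatter); both lie beyond the scatter, so on this small set compound 3 is the strongest. Between compound 1 and compound 2 the step is a 1.5-fold lower number from compound 1 to compound 2 (0.17 log units; within the scatter), which is within the scatter.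

Compound 4, `O=C(Nc1ccc(Oc2ccnc3[nH]ccc23)c(F)c1)c1cc(-c2ccc(F)cc2)ccn1`, has not yet been measured. It differs from compound 3 in one place: fluoro in place of methoxy on an aromatic carbon. Going by the values given here, two measured steps bear on this change. The step from hydrogen to methoxy at this carbon, a 4.8-fold lower number from compound 1 to compound 3 (0.68 log units; beyond the scatter), and the step from ethyl to methoxy, a 3.2-fold lower number from compound 2 to compound 3 (0.51 log units; beyond the scatter), both show that the methoxy goes with the lowest number of the three. Taking the methoxy away again is therefore expected to cost some of that gain, and fluoro is a different small group from hydrogen or ethyl, so the size is uncertain. The expectation for compound 4 in this assay is a modest rise, a 2.9-fold higher number from compound 3 to compound 4 (0.46 log units; beyond the scatter). Compound 4 is estimated at 3000 nM, within a range of 1200 nM to 8000 nM.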

Compound 4, half-maximal inhibitory concentration: 1090 nM
Estimate against measurement, compound 4: 2.8-fold (0.44 log units) above; measured number outside the range, below it.
By their numbers in this assay, from the lowest: compounds 3 and 4 (each within the scatter of the next); then compounds 2 and 1 (each within the scatter of the next).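

In this assay, fluoro and methoxy on this aromatic carbon cannot be told apart, with a 1.0-fold higher number from compound 3 to compound 4 (0.02 log units; within the scatter), so the low number of compound 3 does not depend on methoxy alone, even though this swap removes the oxygen and the hydrogen-bond acceptor counted for methoxy. Compound 4 also keeps the distance from the other two compounds that compound 3 showed, with a 3.1-fold lower number from compound 2 to compound 4 (0.49 log units; beyond the scatter) and a 4.5-fold lower number from compound 1 to compound 4 (0.66 log units; beyond the scatter), both beyond the scatter, so at this carbon two different groups now give numbers clearly lower than those with hydrogen or ethyl. No measurement shown here explains why fluoro and methoxy match at this carbon or why ethyl does not.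

As far as these compounds go, with only four compounds, it remains open whether other groups at this carbon, such as chloro, an amine or a carboxylic acid, would fall with fluoro and methoxy or with hydrogen and ethyl. From the compounds shown here alone, it is also open whether fluoro and methoxy would still match at another carbon of this ring, since every substituted compound here carries its group para to the same large group.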